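The source may report more compounds than this note shows. Statements on the series, on what has been measured and on what is new or still open speak of the compounds shown alone.

Compounds measured in an ADME assay on microsomes from liver (Homo sapiens) for metabolic stability, tested at 2.5 uM; on this read-out higher numbers stand for fast clearance and lower numbers for slow clearance:
Compound 1 `COc1ccc(S(=O)(=O)c2cnc3cc(F)ccc3c2-c2ccc(Cl)cc2)cc1` gives 1.28 mL/min.
Compound 2 `O=S(=O)(c1ccc(F)c(F)c1)c1cnc2cc(F)ccc2c1-c1ccc(Cl)cc1` gives 0.01 mL/min.
Compound 3 `O=S(=O)(c1cccc(F)c1)c1cnc2cc(F)ccc2c1-c1ccc(Cl)cc1` gives 0.98 mL/min.

Compound 1 holds the highest of the three numbers, though compound 3 sits close, with a 1.3-fold lower number from compound 1 to compound 3 (0.12 log units; within the scatter), while compound 2 is far off, with a 130-fold lower number from compound 1 to compound 2 (2.11 log units; beyond the scatter). Compound 4 `COc1ccc(S(=O)(=O)c2cnc3cc(F)ccc3c2-c2cccc(F)c2)cc1` differs from compound 1 in one place: 3-fluorophenyl in place of 4-chlorophenyl on an aromatic carbon. Among the compounds with values here, none of the measured steps touches that position: the two steps from compound 1 change the group on the sulfonyl sulfur, and the step of a 98-fold higher number from compound 2 to compound 3 (1.99 log units; beyond the scatter) puts hydrogen in place of fluoro on that same group. Within the data shown here, with no step bearing directly on the change, no shift beyond the scatter is expected for compound 4, a 1.0-fold higher number from compound 1 to compound 4 (0.01 log units; within the scatter). Compound 4 is therefore estimated at 1.3 mL/min in this assay, between 0.4 mL/min and 4 mL/min.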

Compound 4, intrinsic clearance in a liver preparation (reported as CLH), per the amount of preparation that the assay uses: 2.94 mL/min
Compound 4: the middle estimate sits 2.3-fold (0.35 log units) below what was measured, within the range that was stated.
By their numbers in this assay, from the lowest: compound 2; then compounds 3 and 1 (each within the scatter of the next); then compound 4.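

Within the data shown here, the position on the core that carries this aryl group is not silent in this assay: with 3-fluorophenyl in place of 4-chlorophenyl there is a 2.3-fold higher number from compound 1 to compound 4 (0.36 log units; beyond the scatter) as a modest step, the first reading at this position. That step is far smaller than the largest one on the sulfonyl group, a 130-fold lower number from compound 1 to compound 2 (2.11 log units; beyond the scatter) in the other direction. No evidence at hand accounts for the rise.

This single change moves the fluorine's place and swaps the halogen together, so the two effects stay unseparated. As far as these compounds go, whether 4-fluorophenyl, or an amine or a carboxylic acid on this ring, would shift clearance further remains open.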